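The source may hold more compounds than are shown below. What is called first, only, known or untested is meant among the compounds shown, and "the series" means these compounds.

Measured in an ADME assay; a higher number here means that the compound lasts longer, a lower number that the compound disappears faster:
Compound 1 `COc1ccc(C[S+]([O-])c2ncccc2C(=O)Nc2ccncc2)c(OCCF)c1`: < 0.02 h
Compound 2 `COc1cc(OC)c(C[S+]([O-])c2ncccc2C(=O)Nc2ccncc2)c(OC)c1`: < 0.02 h
Compound 3 `COc1cc(C)c(C[S+]([O-])c2ncccc2C(=O)Nc2ccncc2)c(OC)c1`: < 0.02 h

Compound 1 reads < 0.02 h and this reading is a limit of the assay and not a number. Compound 2 and compound 3 are limits too, so nothing ranks compound 1 against them. The evidence amounts to the limit of < 0.02 h in this assay, at which 3 of the 3 values shown sit.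

Compound 4 `COc1ccc(C[S+]([O-])c2ncccc2C(=O)Nc2ccncc2)cc1` differs from compound 1 at one place, with hydrogen in place of 2-fluoroethoxy on an aromatic carbon, ortho to a large group (hydrogen in place of 2-fluoroethoxy on an aromatic carbon).

Among the compounds with values here, the only measured step, a step that the two limits leave unreadable from compound 2 to compound 3, swaps methyl for methoxy, removes no group and gives no size to carry over. Within the data shown here, no measured step of readable size bears on this change, so nothing supports expecting a shift beyond the scatter in this assay, in either direction. The estimated step is a step that the limit leaves unreadable from compound 1 to compound 4. Another limit would be no surprise. The estimated half-life for compound 4 is 0.015 h, with an expected range of 0.005 h to 0.04 h.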

Compound 4, half-life: 2.14 h
Estimate against measurement, compound 4: 140-fold (2.15 log units) below; measured number above the stated range.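

In this assay, hydrogen in place of 2-fluoroethoxy on this aromatic carbon, ortho to a large group, gives an at least 100-fold higher number from compound 1 to compound 4 (2.02 log units; beyond the scatter), the only step among these compounds with a readable size. This shows that the place is not indifferent: with the rest of the structure unchanged, taking away this one chain brings compound 4 off the limit where the other compounds sit. The true size of the step remains unknown, since the reading for compound 1 is a limit of the assay and not a number: the limit of < 0.02 h in this assay, at which 3 of the 4 values shown sit.

The step from compound 2 to compound 3 cannot be read, so the compounds shown do not tell how other changes on this ring behave. Going by these compounds, it also remains open whether a single fluorine atom, a shorter ethoxy chain or an amine on this carbon would keep the half-life of compound 4.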